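The source may hold more compounds than are shown below. What is called first, only, known or untested is meant among the compounds shown, and "the series" means these compounds.

Measured so far in an ADME assay on the whole organism for cytotoxicity, with Artemia salina as the target, with a stated time of 24 h; on this read-out lower numbers stand for an effect already at smaller amounts and higher numbers for an effect only at larger amounts of compound:
compound 1 `COc1ccc(/C=C/C(=O)c2ccccc2NC(=O)NS(=O)(=O)c2ccc(C)cc2)cc1OC` gives 12.9 ug/mL;
compound 2 `COc1ccc(/C=C/C(=O)c2ccccc2NC(=O)NS(=O)(=O)c2ccc(C)cc2)c(OC)c1` gives 16 ug/mL;
compound 3 `Cc1ccc(S(=O)(=O)NC(=O)Nc2ccccc2C(=O)/C=C/c2ccccc2[N+](=O)[O-])cc1` gives 40.1 ug/mL.

Compound 3 carries the highest number of the three. The two steps that lead to it are a 3.1-fold higher number from compound 1 to compound 3 (0.49 log units; beyond the scatter) and a 2.5-fold higher number from compound 2 to compound 3 (0.40 log units; beyond the scatter), both beyond the scatter, whereas the step of a 1.2-fold higher number from compound 1 to compound 2 (0.09 log units; within the scatter) stays within it; so the two dimethoxy patterns are not separated here, and only the 2-nitrophenyl compound stands apart.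

Compound 4 `Cc1ccc(S(=O)(=O)NC(=O)Nc2ccccc2C(=O)/C=C/c2cc(O)ccc2[N+](=O)[O-])cc1` differs from compound 3 by hydroxy in place of hydrogen on an aromatic carbon. Among the measured compounds shown here, no measured step adds or removes a single hydroxy group; the only steps on record exchange the whole aryl ring, and they bear on this change only loosely. With nothing closer to go on, the working expectation is a step within the scatter, in no definite direction, with a wide allowance for error. Compound 4 is expected to give 40 ug/mL, with a range from 18 ug/mL to 90 ug/mL. The expected step is a 1.0-fold lower number from compound 3 to compound 4 (0.00 log units; within the scatter).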

Compound 4, concentration for half-maximal effect: 18.3 ug/mL
Estimate against measurement, compound 4: 2.2-fold (0.34 log units) above; low and high end bracket the measured number.
By their numbers in this assay, from the lowest: compounds 1, 2 and 4 (each within the scatter of the next); then compound 3.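

Hydroxy in place of hydrogen, para to a nitro group, moves the number in this assay: a 2.2-fold lower number from compound 3 to compound 4 (0.34 log units; beyond the scatter), so this position on the 2-nitrophenyl ring responds to a single added group. The aryl exchanges now read a 1.1-fold higher number from compound 2 to compound 4 (0.06 log units; within the scatter) and a 1.4-fold higher number from compound 1 to compound 4 (0.15 log units; within the scatter), so 5-hydroxy-2-nitrophenyl is not separated from either dimethoxyphenyl pattern, and a nitro group on the ring does not by itself set a compound apart, since only compound 3 stands alone. No measured evidence on the origin of this step is at hand.

As far as these compounds go, whether an amine or a methoxy group at this place would read like hydroxy stays open. Also open, from the compounds shown here alone, is whether hydroxy on a dimethoxyphenyl ring would shift the number at all.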